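The source may report more compounds than this note shows. Statements on the series, on what has been measured and on what is new or still open speak of the compounds shown alone.

Measured compounds:
Compound 1 `Cc1cc(-n2ccnc2)cn2c(CSCCc3ccccc3)cnc12`: 23 ug/mL
Compound 2 `Cc1cc(N2CCN(C)CC2)c2ncc(CSCCc3ccccc3)n2c1`: "not determined" (no result reported)

Among the measured compounds shown here, in an ADME assay on HEL cells (Homo sapiens) for cytotoxicity, with a stated time of 3 days (on this read-out lower numbers stand for higher toxicity in this test and higher numbers for lower toxicity in this test), compound 1 gives 23 ug/mL, the only number in this small set. Compound 2 was also entered in this assay but the result is recorded as "not determined" (no result reported), so no number exists for it and it cannot be placed against compound 1 on this read-out. Compound 3 `Cc1cc(Sc2ccc(O)cc2)c2ncc(CSCCc3ccccc3)n2c1` has not been tested yet. It differs from compound 2 in one place: (4-hydroxyphenyl)sulfanyl in place of 4-methylpiperazin-1-yl on an aromatic carbon. For the measured compounds named here, with no number for compound 2 and no measured step between two compounds that differ in one place, nothing in these data points to a change in cytotoxicity in either direction beyond the usual scatter. Going by the values given here, the only guide is compound 1, which shares the core and the side chain of compound 3. Near the value of compound 1, compound 3 is expected to land at roughly 22 ug/mL in this assay, within an estimated range of 8 ug/mL to 60 ug/mL, with a fair chance that only a limit is reported.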

Compound 3, half-maximal cytotoxic concentration: 79 ug/mL
For compound 3 the middle estimate is 3.6-fold (0.56 log units) below the measured one, and the stated range ends below it.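

Among the compounds shown here, with no number for compound 2 in this assay, no step to compound 3 can be read from this result. Whether (4-hydroxyphenyl)sulfanyl in place of 4-methylpiperazin-1-yl changes toxicity in this test stays open, and nothing shown here explains the result for compound 3.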